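The compounds below may be only part of what the source reports. "The series", "measured", "known", "first", "only" and "open" are said of these compounds alone.

Working notes on the series, read in an ADME assay on HaCaT cells (Homo sapiens) for cytotoxicity, read by MTT assay, with a stated time of 48 h; on this read-out higher numbers stand for weaker inhibition and lower numbers for stronger inhibition. Compound 1 (`Cc1ccc2[nH]c(-c3cn(-c4ccccc4)nc3-c3ccc(Cl)cc3)nc2c1`) gives > 50000 nM, which is a limit of the assay and not a number. Compound 2 (`COc1ccc(-c2nn(-c3ccccc3)cc2-c2nc3cc(C(F)(F)F)ccc3[nH]2)cc1`) gives > 50000 nM, which is likewise a limit. Among the measured compounds shown here, compound 2 therefore has no numerical position, and the only other value is also a limit: the limit of > 50000 nM in this assay, at which 2 of the 2 values shown sit. No order can be drawn between these two compounds.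

Next comes compound 3 (`COc1ccc(-c2nn(-c3ccccc3)cc2-c2nc3cc(C)ccc3[nH]2)cc1`), which differs from compound 2 in one place: methyl in place of trifluoromethyl on an aromatic carbon of a six-membered aromatic ring of carbon only, part of a fused or bridged system of two rings, (methyl in place of trifluoromethyl on an aromatic carbon). For the measured compounds named here, no step between measured compounds is available to size this change. In this assay no step beyond the usual scatter is expected, and no direction is favoured. That expectation rests on compound 2, whose > 50000 nM is a limit. The estimated step is a step that the limit leaves unreadable from compound 2 to compound 3. For compound 3 the estimated value is 55000 nM, with an expected range from 25000 nM to 100000 nM.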

Compound 3, half-maximal inhibitory concentration: > 50000 nM
Compound 3: a limit, no number; the forecaster's own chance of this, stated with the estimate: 80%; the middle value is on the limit's open side.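

Compound 3 gives > 50000 nM, which is a limit and not a number. No step can be read from compound 1 or compound 2 to compound 3, and no order can be drawn among the three: the limit of > 50000 nM in this assay, at which 3 of the 3 values shown sit.

The compounds shown leave open whether methyl in place of trifluoromethyl, or methoxy in place of chloro, changes the value at all.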